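The source may hold more compounds than are shown below. What is called first, only, known or untested is meant among the compounds shown, and "the series" means these compounds.

Working notes on the amidine series. The read-out is a functional assay on SH-SY5Y cells (Homo sapiens) for cytotoxicity, read by MTT assay, with stated times of 8 h, 30 min and 12 h, tested at 0.5 uM; a lower number here means a weaker effect, a higher number a stronger effect of the compound at the concentration tested. Compound 1, `N=C(NCc1ccc(O)cc1)[C@@H]1CCC(=O)N1Cc1ccccc1[N+](=O)[O-]`, carries a 4-hydroxybenzyl group on the amidine nitrogen and a nitro-substituted benzyl on the lactam nitrogen; in this assay compound 1 gives 26.9%. Compound 2, `COc1ccc(CN2C(=O)CC[C@H]2C(=N)NCc2ccccc2)cc1`, has a methoxybenzyl on the lactam nitrogen and a plain benzyl on the amidine nitrogen; in this assay compound 2 gives 21%. Of the two numbers, the value of compound 2 lies within the scatter of that of compound 1, so the two cannot be ranked on these data. Compound 1 and compound 2 differ in more than one place, so their gap is not assigned to any single change.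

Compound 3, `COc1ccc(CN2C(=O)CC[C@H]2C(=N)NCc2ccc(O)cc2)cc1`, is compound 2 with one change: hydroxy in place of hydrogen on an aromatic carbon. For the measured compounds named here, no measured pair in the set isolates this change. Since compound 1, which carries the hydroxy group on the same benzyl, gives 26.9%, the step from compound 2 to compound 3 is expected to be small, a number 3 percentage points higher from compound 2 to compound 3 (within the scatter), and not beyond the scatter. Compound 3 is therefore estimated at 24%, with a range of 10% to 38%.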

Compound 3, a percentage reported as activity, at one concentration (the size of the read-out at that concentration, not a potency): 20.5%
Compound 3: middle estimate off by 3.5 percentage points, on the high side, within the range that was stated.
By their numbers in this assay, from the lowest: compounds 3, 2 and 1 (each within the scatter of the next).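

For the compounds shown here, the step of a number 0.5 percentage points lower from compound 2 to compound 3 (within the scatter) in this assay gives the first direct reading of hydroxy in place of hydrogen on an aromatic carbon, para to a large group, and shows that benzyl and 4-hydroxybenzyl cannot be told apart at the concentration tested. Going by these compounds alone, the step of a number 6.4 percentage points lower from compound 1 to compound 3 (within the scatter) likewise gives the first single-place reading of 4-methoxyphenyl in place of 2-nitrophenyl on a saturated chain carbon bound to an amide-type nitrogen in a ring, with the 4-hydroxybenzyl group held the same, and these two groups cannot be told apart here either. No supporting data on hand bear on why either change leaves the read-out within the scatter.

Both readings rest on one pair each, so they say nothing about whether a group of another kind at the same para place, such as an amine or a carboxylic acid, would also stay within the scatter. Going by these compounds, it also stays open whether a longer chain in place of the benzyl link, or a nitro or methoxy group at another place on the ring, would move the read-out beyond the scatter.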